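From compound 3 to compound 4: the sulfonyl substituent

The source may report more compounds than this note shows. Statements on the series, on what has been measured and on what is new or still open speak of the compounds shown alone.

Values in an ADME assay on microsomes from liver (Mus musculus) for metabolic stability, read by LC-MS, with a stated time of 40 min, tested at 0.5 uM; a lower number here means slower removal, a higher number faster removal of the compound:
- compound 1 `CC(C)(C)NS(=O)(=O)c1cccc(NC(=O)c2ccc(NC3(CO)CC3)cc2N2CCC3(CC2)CC3)n1`: 58 mL.min-1.g-1
- compound 2 `CC(C)(C)NS(=O)(=O)c1cccc(NC(=O)c2ccc(NS(C)(=O)=O)cc2N2CCC3(CC2)CC3)c1`: 81 mL.min-1.g-1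
- compound 3 `CC(C)(C)NS(=O)(=O)c1cccc(NC(=O)c2cccnc2N2CCC3(CC2)CC3)c1`: > 399 mL.min-1.g-1 (a limit)

Compound 1 and compound 2 carry numbers, while compound 3 carries only a limit: the limit of > 399 mL.min-1.g-1 in this assay, at which 1 of the 3 values shown sits.

Compound 4 `O=C(Nc1cccc(S(=O)(=O)N2CCCC2)c1)c1cccnc1N1CCC2(CC1)CC2` differs from compound 3 as follows: pyrrolidin-1-yl in place of (tert-butyl)amino on a sulfonyl sulfur. In short, the (tert-butyl)sulfamoyl becomes (pyrrolidin-1-yl)sulfonyl. For the measured compounds named here, no measured pair covers this change, so the expectation stays close to compound 3 at > 399 mL.min-1.g-1, a limit. The estimated step of an at least 1.3-fold lower number from compound 3 to compound 4 (0.12 log units; that floor lies within the scatter) is small, and removal is expected to remain fast in this assay. The estimate for compound 4 is 300 mL.min-1.g-1, with an expected range of 130 mL.min-1.g-1 to 400 mL.min-1.g-1.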

Compound 4, intrinsic clearance in microsomes: > 399 mL.min-1.g-1
Compound 4: only a limit was reported (the forecaster's own chance of this, stated with the estimate: 45%); middle value at least 1.3-fold (0.12 log units) from the limit.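

No step can be read from compound 3 to compound 4 in this assay, because both carry only a limit: the limit of > 399 mL.min-1.g-1 in this assay, at which 2 of the 4 values shown sit.

The compounds shown leave open what (pyrrolidin-1-yl)sulfonyl in place of (tert-butyl)sulfamoyl does to intrinsic clearance in microsomes when both values are numbers rather than limits.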